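The source may hold more compounds than are shown below. What is called first, only, known or untested is meant among the compounds shown, and "the series" means these compounds.

Of the compounds shown here, two built on a shared core have so far been tested in a physicochemical assay for solubility, in phosphate buffer, measured as kinetic solubility, with a stated time of 1 h, at pH 7.4; a lower number here means a less soluble compound, a higher number a more soluble compound. Compound 1 `Cc1cc(C)cc(NC(=O)COc2cc(C)nc3ccc(Cl)cc23)c1` gives 8000 nM. Compound 2 `COc1ccc2nc(C)cc(OCC(=O)Nc3cc(C)ccc3C)c2c1` gives 45500 nM in this assay, the higher of the two numbers, and the gap between compound 2 and compound 1 lies beyond the usual scatter of repeated measurements. Compound 3 `COc1ccc2nc(C)cc(OCC(=O)Nc3ccc(F)cc3)c2c1` has not yet been measured. It differs from compound 2 in a single place: 4-fluorophenyl in place of 2,5-dimethylphenyl on an amide-type nitrogen. The group that enters has fewer heavy atoms than the one that leaves, and a compound of this kind is expected to dissolve at least as readily as before. The step of a 1.4-fold higher number from compound 2 to compound 3 (0.15 log units; within the scatter) is therefore expected to be a small rise, close to the edge of the scatter rather than clearly beyond it. Compound 3 is estimated to give 65000 nM in this assay, with a likely range from 25000 nM to 160000 nM.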

Compound 3, solubility: 104000 nM
Estimate against measurement, compound 3: 1.6-fold (0.20 log units) below, and the stated range covers the measured number.
By their numbers in this assay, from the lowest: compound 1; then compound 2; then compound 3.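

In this assay, putting 4-fluorophenyl in place of 2,5-dimethylphenyl on the amide-type nitrogen gives a 2.3-fold higher number from compound 2 to compound 3 (0.36 log units; beyond the scatter). Going by these compounds alone, this is the first comparison here that changes one place only, and it shows that this position alone can move the read-out beyond the usual scatter. The step appears even though both groups hold one six-membered aromatic ring of carbon only and no net charge, with 7 heavy atoms entering and 8 leaving, and no available evidence explains it.

From the compounds shown here alone, this swap removes the two methyl groups and adds the fluorine at once, so the contribution of each remains open. Also open, going by these compounds, are how a plain phenyl group or a phenyl ring bearing an amine or a carboxylic acid would behave here, and whether the same swap would give a similar step on the core of compound 1.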